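Dropping One Methoxy Group from Compound 2

The source may report more compounds than this note shows. Statements on the series, on what has been measured and on what is new or still open speak of the compounds shown alone.

Compound 1 `Nc1cc(N)c2nc(-c3ccccc3)c(Sc3ccc(F)cc3)nc2c1` — < 100000 nM
Compound 2 `COc1cc(CNc2nc3cc(N)cc(N)c3nc2-c2ccccc2)cc(OC)c1OC` — 11200 nM
Compound 3 `Nc1cc(N)c2nc(-c3ccccc3)c(Sc3ccc(Cl)c(Cl)c3)nc2c1` — 3090 nM

Of the compounds shown here, three sharing one core have been tested in a functional assay on ACHN cells (Homo sapiens) for inhibition, read by sulforhodamine B assay, with a stated time of 48 h; on this read-out higher numbers stand for weaker inhibition of growth and lower numbers for stronger inhibition of growth. Compound 2 gives 11200 nM, the highest of the two numbers shown. Compound 3 gives 3090 nM, a lower number, and the gap between compound 2 and compound 3 lies beyond the usual scatter. For compound 1 the value < 100000 nM is a limit of the assay rather than a number. For the measured compounds named here, the only step between measured compounds, a step that the limit leaves unreadable from compound 1 to compound 3, cannot be read in size because of the limit of < 100000 nM in this assay, at which 1 of the 3 values shown sits.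

Compound 4 `COc1ccc(CNc2nc3cc(N)cc(N)c3nc2-c2ccccc2)cc1OC` differs from compound 2 by hydrogen in place of methoxy on an aromatic carbon. Going by the values given here, no measured step touches this part of the structure, so nothing among the measured compounds speaks for a shift in either direction. The step of a 1.0-fold lower number from compound 2 to compound 4 (0.01 log units; within the scatter) is therefore expected to stay within the scatter. Compound 4 is estimated to give about 11000 nM, with a range from 4000 nM to 30000 nM.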

Compound 4, concentration for total growth inhibition: 33100 nM
The estimate for compound 4 lay 3.0-fold (0.48 log units) below the measured number, outside the stated range (above it).
By their numbers in this assay, from the lowest: compound 3; then compound 2; then compound 4.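

In this assay this methoxy group turns out not to be neutral: replacing it with hydrogen on the aromatic carbon ortho to a methoxy group and meta to a large group gives a 3.0-fold higher number from compound 2 to compound 4 (0.47 log units; beyond the scatter), so the change goes with weaker inhibition of growth. For the compounds shown here, this is the first step that can be read in size, and it shows that the number responds to a change at this position of the ring, though modestly and in a single pair of compounds. Nothing measured here explains why the number moves.

The compounds shown leave open whether an ethoxy group, a hydroxyl group or a chlorine at this position would stay close to compound 2 or move further from it. They also leave open whether replacing either remaining methoxy group with hydrogen would shift the number in the same direction.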